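The source may hold more compounds than are shown below. What is called first, only, known or untested is meant among the compounds shown, and "the series" means these compounds.

Measured so far in an ADME assay on HEK293 cells (Homo sapiens) for cytotoxicity, read by resazurin assay, with a stated time of 48 h; on this read-out higher numbers stand for lower toxicity in this test and lower numbers for higher toxicity in this test
Compound 1 `Cc1ccc(S(=O)(=O)Nc2ccc(-c3nc4ccccc4o3)cc2)cc1` gives 88000 nM
Compound 2 `O=S(=O)(Nc1ccc(-c2nc3ccccc3o2)cc1)c1ccccc1Cl` gives > 100000 nM as a limit, not a number
Compound 3 `O=S(=O)(Nc1ccc(-c2nc3ccccc3o2)cc1)c1ccc(F)c(C(F)(F)F)c1` gives 82000 nM

Compound 2 stands at the limit of > 100000 nM in this assay, at which 1 of the 3 values shown sits, and so has no exact value. Compound 4 `CS(=O)(=O)Nc1ccc(-c2nc3ccccc3o2)cc1` differs from it by methyl in place of 2-chlorophenyl on a sulfonyl sulfur, with methyl in place of 2-chlorophenyl on a sulfonyl sulfur. Among the measured compounds shown here, one measured step bears on this change at that sulfur: an at least 1.1-fold higher number from compound 1 to compound 2 (0.05 log units; that floor lies within the scatter). For the measured compounds named here, no measured step replaces the ring on that sulfur with methyl, so the evidence is thin. No step beyond the scatter is therefore expected in this assay, and the estimated change is an at least 1.0-fold lower number from compound 2 to compound 4 (0.02 log units; that floor lies within the scatter) in either direction. For compound 4 the expected value is 95000 nM, with an estimated range from 50000 nM to 180000 nM.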

Compound 4, half-maximal cytotoxic concentration: > 100000 nM
Compound 4: no number, only a limit; the forecaster's own chance of this, stated with the estimate: 50%; at least 1.0-fold (0.02 log units) between middle value and limit.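

In this assay, among the compounds shown here, compound 4 gives > 100000 nM, a limit and not a number, so a ring on the sulfonyl sulfur is not needed to reach this limit, which the earlier compounds, all with a ring there, could not show. Methyl in place of 4-methylphenyl gives an at least 1.1-fold higher number from compound 1 to compound 4 (0.05 log units; that floor lies within the scatter), while the step between compound 2 and compound 4 cannot be read. Compound 4 thus stands with compound 2: the limit of > 100000 nM in this assay, at which 2 of the 4 values shown sit.

Going by these compounds, the true values of both stay unknown, and so does any order between them. On these data alone, whether an amine or a longer chain on that sulfur would stay at this limit also remains open.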